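The source may hold more compounds than are shown below. What is called first, only, known or untested is meant among the compounds shown, and "the series" means these compounds.

Three compounds share one core and differ only in the group on the aniline ring. Compound 1 `O=C(/C=C\Nc1ccc(F)cc1)c1cn(-c2ccccc2)nc1-c1ccc(F)cc1` carries fluoro and in a functional assay on U-87MG ATCC cells (Homo sapiens) for antiproliferative activity, read by MTT assay, with a stated time of 48 h (a higher number here means a weaker inhibitor, a lower number a stronger inhibitor), compound 1 gives 18200 nM. Compound 2 `O=C(/C=C\Nc1ccc(Cl)cc1)c1cn(-c2ccccc2)nc1-c1ccc(F)cc1` carries chloro, and in this assay compound 2 gives 8900 nM, a step of a 2.0-fold lower number from compound 1 to compound 2 (0.31 log units; beyond the scatter). Compound 3 `O=C(/C=C\Nc1ccc(C(F)(F)F)cc1)c1cn(-c2ccccc2)nc1-c1ccc(F)cc1` carries trifluoromethyl; in this assay compound 3 reaches only a limit of the assay, > 50000 nM. Compound 3 thus stands at the limit of > 50000 nM in this assay, at which 1 of the 3 values shown sits, and is the weakest of the three, with steps of an at least 2.7-fold higher number from compound 1 to compound 3 (0.43 log units; beyond the scatter) and an at least 5.6-fold higher number from compound 2 to compound 3 (0.74 log units; beyond the scatter).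

Compound 4 `O=C(/C=C\Nc1ccc(O)cc1)c1cn(-c2ccccc2)nc1-c1ccc(F)cc1` makes the change (hydroxy in place of trifluoromethyl on an aromatic carbon). For the measured compounds named here, no measured step involves hydroxy, so only the two steps that reach compound 3 bear on it: both show that replacing trifluoromethyl by a smaller group lowers the number. A lower number than the limit of compound 3 is therefore expected, as a step of an at least 2.5-fold lower number from compound 3 to compound 4 (0.39 log units; beyond the scatter). Compound 4 is estimated at 20000 nM, within a range of 6000 nM to 60000 nM.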

Compound 4, half-maximal inhibitory concentration: 4700 nM
Beside the measured number, compound 4's estimate is 4.3-fold (0.63 log units) above it; measured number below the stated range.
By their numbers in this assay, from the lowest: compounds 4 and 2 (each within the scatter of the next); then compound 1. At a limit, above all of these: compound 3.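

Exchanging trifluoromethyl, with 4 heavy atoms and no hydrogen-bond donor, for hydroxy, with 1 heavy atom and 1 hydrogen-bond donor, gives an at least 10-fold lower number from compound 3 to compound 4 (1.02 log units; beyond the scatter) and so shows that this position on the aniline ring can tolerate a small oxygen-bearing group. Hydroxy also gives a 3.9-fold lower number from compound 1 to compound 4 (0.59 log units; beyond the scatter) while the comparison with chloro gives a 1.9-fold lower number from compound 2 to compound 4 (0.28 log units; within the scatter) so that hydroxy and chloro cannot be told apart here. From the compounds shown here alone, the true size of the step from trifluoromethyl remains unknown, as compound 3 has only a limit of the assay: the limit of > 50000 nM in this assay, at which 1 of the 4 values shown sits.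

Going by these compounds, whether an amine or a carboxylic acid at this position would match hydroxy remains open. So does whether a methoxy group, which keeps the oxygen but not its hydrogen, would hold the same level.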